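The source may report more compounds than this note shows. Statements on the series, on what has been measured and on what is new or still open speak of the compounds shown alone.

Measured compounds:
compound 1 `Cc1ccc(F)cc1NC(=O)Nc1cc(C(C)(C)C)nn1-c1ccccc1`: 6 degrees C
compound 2 `Cn1nc(-c2ccccc2)cc1NC(=O)Nc1cc(C(F)(F)F)cc(C(F)(F)F)c1`: 1.9 degrees C

In an assay on isolated protein for inhibition of STE20-like serine/threonine-protein kinase (Homo sapiens), read by thermal shift assay, tested at 10 uM (a higher number here means that the compound stabilises the target more against heat, a lower number that the compound stabilises the target less), compound 1 gives 6 degrees C, the higher of the two numbers; compound 2 gives 1.9 degrees C, a gap that lies beyond the usual scatter. Compound 3 `CC(C)(C)c1cc(NC(=O)Nc2cc(F)cc(F)c2)n(-c2ccccc2)n1` is not yet measured. It differs from compound 1 by 3,5-difluorophenyl in place of 5-fluoro-2-methylphenyl on an amide-type nitrogen. Among the measured compounds shown here, with no step between measured compounds sharing this change, the expectation rests on compound 1 alone, and the estimate is a small downward step of a number 1.5 degrees C lower from compound 1 to compound 3 (beyond the scatter), near the edge of the scatter. Compound 3 is thus expected to give 4.5 degrees C, with a range from 2.5 degrees C to 6.5 degrees C.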

Compound 3, shift of the target's melting temperature: 3 degrees C
Compound 3: middle estimate off by 1.5 degrees C, on the high side; the measured number falls inside the stated range.
By their numbers in this assay, from the lowest: compound 2; then compound 3; then compound 1.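

On the amide-type nitrogen of the shared core, 3,5-difluorophenyl in place of 5-fluoro-2-methylphenyl gives, in this assay, a number 3.0 degrees C lower from compound 1 to compound 3 (beyond the scatter). This first one-place comparison shows that the read-out responds to the aryl group at this place, even though both groups have the same count of heavy atoms and neither has hydrogen-bond donors or acceptors. Nothing measured here accounts for this step.

Which part of the change carries the step stays open, the loss of the methyl or the placing of the fluorines. Also open, as far as these compounds go, is how a methoxy or an amine on this phenyl ring would read.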